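Aryl amine series: dropping one chloro from compound 2

The source may hold more compounds than are shown below. What is called first, only, known or untested is meant among the compounds shown, and "the series" means these compounds.

In a functional assay on RXF 393 cells (Homo sapiens) for inhibition, read by sulforhodamine B assay, with a stated time of 48 h (a higher number here means a weaker inhibitor of growth, a lower number a stronger inhibitor of growth), compound 1 `CN1CCN(CCCOc2cccc3nc(Nc4ccc(F)c(F)c4)ccc23)CC1` gives 2110 nM. In this assay compound 2 `CN1CCN(CCCOc2cccc3nc(Nc4cc(Cl)cc(Cl)c4)ccc23)CC1` gives 1670 nM. Going by the values given here, the single measured step, a 1.3-fold lower number from compound 1 to compound 2 (0.10 log units; within the scatter), swaps one dihalogenated phenyl for another and stays within the scatter, so compound 2 and compound 1 sit within the scatter of each other and neither is separated from the other on the numbers so far. Compound 3 `CN1CCN(CCCOc2cccc3nc(Nc4cccc(Cl)c4)ccc23)CC1` is not yet measured; against compound 2 the change is hydrogen in place of chloro on an aromatic carbon. Among the compounds with values here, no measured step removes a single halogen from this phenyl ring, and the only step touching the ring, a 1.3-fold lower number from compound 1 to compound 2 (0.10 log units; within the scatter), lies within the scatter. The expectation for compound 3 in this assay is therefore a step of a 1.3-fold higher number from compound 2 to compound 3 (0.12 log units; within the scatter), nothing beyond the scatter in either direction. Compound 3 is estimated at 2200 nM, with a range of 1000 nM to 5000 nM.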

Compound 3, concentration for 50% growth inhibition: 1850 nM
Compound 3: the middle estimate sits 1.2-fold (0.08 log units) above what was measured; measured number inside the range.
By their numbers in this assay, from the lowest: compounds 2, 3 and 1 (each within the scatter of the next).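

In this assay, going by these compounds alone, taking one chloro off the 3,5-dichlorophenyl ring to give the 3-chlorophenyl ring is the first measured loss of a single halogen, and it stays within the scatter: a 1.1-fold higher number from compound 2 to compound 3 (0.04 log units; within the scatter). The comparison with the 3,4-difluorophenyl ring also stays within the scatter, a 1.1-fold lower number from compound 1 to compound 3 (0.06 log units; within the scatter), so the three halogenated phenyl rings shown cannot be told apart on these numbers, and the second chloro shows no measurable contribution at this position. No evidence is available on why this change leaves the reading within the scatter.

Still open is whether the last chloro matters, since an unsubstituted phenyl ring is not among the compounds shown. Also open, on these data alone, is whether a non-halogen group on this ring, such as methoxy or trifluoromethyl, would give a step beyond the scatter.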